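Working notes: cytotoxicity across three analogues of one core

This account rests on a few compounds, and the source may have more. Where it says the series, first, only, none or still open, it means among the compounds named here.

Measured so far in an ADME assay on Vero cells (Chlorocebus sabaeus) for cytotoxicity, read by resazurin assay, with a stated time of 3 days; on this read-out lower numbers stand for stronger inhibition and higher numbers for weaker inhibition:
- compound 1 `CCN(CC)c1cc2[nH]c(C3CCCCC3)nc2cc1NC(=O)c1cnccn1`: > 100 ug/mL
- compound 2 `CCN(CC)c1cc2[nH]c(C3CCCCC3)nc2cc1NC(=O)OCCOCCOC`: > 100 ug/mL

In this assay compound 1 gives only a limit, > 100 ug/mL. Compound 2 likewise gives only a limit in this assay, > 100 ug/mL. The step that the two limits leave unreadable from compound 1 to compound 2 therefore cannot be read, since both values sit at the limit of > 100 ug/mL in this assay, at which 2 of the 2 values shown sit. Going by the values given here, compound 2 thus stands only as a limit in this assay, without a number of its own; the one further value shown beside it is a limit as well.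

Compound 3 `CCN(CC)c1cc2[nH]c(C3CCCCC3)nc2cc1NC(=O)c1ccc(F)cc1F` differs from compound 2 in a single place: 2,4-difluorophenyl in place of 2-(2-methoxyethoxy)ethoxy on a carbonyl carbon. Among the compounds with values here, the only measured step that bears on this position is the one from compound 1 to compound 2, and its size is not readable, so it sets neither a direction nor a magnitude. Given that both measured values in this assay are limits, the expected step of a number no higher from compound 2 to compound 3 (the limit leaves the size open) is none beyond the scatter. Compound 3 is accordingly estimated at 100 ug/mL in this assay, with a range from 40 ug/mL to 250 ug/mL, and is expected most likely to be reported again only as a limit.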

Compound 3, half-maximal inhibitory concentration: > 100 ug/mL
Compound 3: only a limit was reported; the forecaster's own chance of this, stated with the estimate: 65%; the middle value sits exactly at the limit.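

In this assay compound 3 gives > 100 ug/mL, which is a limit and not a number. No step among compound 1, compound 2 and compound 3 can be read, because all three values are limits: the limit of > 100 ug/mL in this assay, at which 3 of the 3 values shown sit.

The compounds shown leave open whether the pyrazin-2-yl, 2-(2-methoxyethoxy)ethoxy and 2,4-difluorophenyl groups on the carbonyl carbon differ at all in this assay.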